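This account rests on a few compounds, and the source may have more. Where it says the series, first, only, none or still open, it means among the compounds named here.

In a functional assay on HT-29 cells (Homo sapiens) for cytotoxicity, read by MTT assay, with a stated time of 72 h (on this read-out lower numbers stand for higher toxicity in this test and higher numbers for lower toxicity in this test), three selenium-bearing compounds have been examined so far. Compound 1 `CCCCC[Se]c1nc(NCc2ccccc2)c2ccccc2n1` carries a pentyl on the selenium. In this assay compound 1 reaches only the limit of > 100000 nM. Compound 2 `[SeH]c1nc(NCc2ccccc2)c2ccccc2n1` carries a hydrogen on that selenium instead; in this assay compound 2 likewise gives only the limit of > 100000 nM. The change between them is pentyl in place of hydrogen on a selenium, and the step that the two limits leave unreadable from compound 2 to compound 1 is consequently of unreadable size. Compound 3 `Nc1nc([SeH])nc2ncccc12` rests on a different core, and how the two cores differ is not broken down here. In this assay compound 3 also stops at the limit of > 100000 nM. Compound 4 `CCCCC[Se]c1nc(N)c2cccnc2n1` has not yet been measured; it differs from compound 3 by pentyl in place of hydrogen on a selenium, the same change as that from compound 2 to compound 1, at the same place. Because (the limit of > 100000 nM in this assay, at which 3 of the 3 values shown sit), no readable value is at hand to anchor a number. The step that the limit leaves unreadable from compound 3 to compound 4 is therefore expected to remain unreadable. Compound 4 is expected to come in near 150000 nM, most likely again as a limit.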

Compound 4, concentration lethal to 50% of the cells: 62100 nM
The estimate for compound 4 lay 2.4-fold (0.38 log units) above the measured number; the range from low to high includes it.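

In this assay pentyl in place of hydrogen on a selenium gives an at least 1.6-fold lower number from compound 3 to compound 4 (0.20 log units; that floor lies within the scatter) and, on the core of compound 3, this floor is all that is established; it does not set the pair apart beyond the usual scatter. On the core of compound 1 the same change cannot be read, so the two steps cannot be compared, because both members of that pair stop at a limit: the limit of > 100000 nM in this assay, at which 3 of the 4 values shown sit. The data therefore neither show that the change carries from one core to the other nor show that it fails to do so.

Going by these compounds, it remains open whether a longer chain such as octyl on the selenium would give a readable number on either core. Also open, on these data alone, is how an amine or a carboxylic acid in place of the pentyl would read in this assay on these two cores.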